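Trimming a Benzyl to a Phenyl on an Amide-Type Nitrogen

The compounds below may be only part of what the source reports. "The series", "measured", "known", "first", "only" and "open" are said of these compounds alone.

Of the compounds shown here, two have so far been tested in a functional assay on MCF7 cells (Homo sapiens) for cytotoxicity, read by MTT assay; a higher number here means a weaker inhibitor, a lower number a stronger inhibitor. Compound 1 `CC(C)[C@H](NC(=S)NCc1ccccc1)c1nc2ccccc2[nH]1` gives 57800 nM in this assay, and compound 2 `C[C@H](NC(=S)NCc1ccccc1)c1nc2ccccc2[nH]1` gives 217000 nM. Of the two numbers, compound 2 holds the higher one and is therefore the weaker inhibitor of the pair. Among the measured compounds shown here, the single measured step, a 3.8-fold higher number from compound 1 to compound 2 (0.57 log units; beyond the scatter), comes from methyl in place of isopropyl on a saturated chain carbon bound to an amide-type nitrogen and an aromatic carbon.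

Compound 3 `C[C@H](NC(=S)Nc1ccccc1)c1nc2ccccc2[nH]1` keeps the methyl of compound 2 and alters a different part of the molecule: phenyl in place of benzyl on an amide-type nitrogen. For the measured compounds named here, no measured step touches this nitrogen, and the one step that exists concerns another site, so it gives little guidance on the size or direction of the change. The effect of removing one carbon between the ring and the nitrogen is therefore unknown from these data, and the most defensible expectation is a step that stays within the scatter, a 1.1-fold lower number from compound 2 to compound 3 (0.04 log units; within the scatter). Compound 3 is thus expected to give about 200000 nM in this assay, with a plausible range from 80000 nM to 500000 nM.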

Compound 3, half-maximal inhibitory concentration: 196000 nM
Estimate against measurement, compound 3: 1.0-fold (0.01 log units) above, and the stated range covers the measured number.
By their numbers in this assay, from the lowest: compound 1; then compounds 3 and 2 (each within the scatter of the next).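

Trimming benzyl to phenyl on the amide-type nitrogen gives a 1.1-fold lower number from compound 2 to compound 3 (0.04 log units; within the scatter) in this assay, so with the methyl in place, these two groups cannot be told apart at this position. The earlier step, on the saturated chain carbon, lay beyond the scatter, whereas this first step at the nitrogen does not: in this pair, the aromatic ring can sit directly on the nitrogen or be held one carbon away from it with no readable change in the number. No supporting data on the compounds are available to explain this result.

The compounds shown leave open whether the same holds when the chain carbon carries isopropyl, since the only isopropyl compound here, compound 1, has benzyl on the nitrogen. They also leave open whether a longer chain such as phenethyl on that nitrogen, or an amine or a carboxylic acid on the phenyl ring, would move the number beyond the scatter, something that a single step within the scatter cannot predict.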